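Methoxy on the Aryl Ring of Two Thiazolopyrimidinones

The source may hold more compounds than are shown below. What is called first, only, known or untested is meant among the compounds shown, and "the series" means these compounds.

Measured compounds:
compound 1 `Cc1nc2sc(-c3ccccc3)nc2c(=O)[nH]1` with 11%
compound 2 `COc1cccc(-c2nc3c(=O)[nH]c(C)nc3s2)c1` with 1%
compound 3 `Cc1nc2sc(Nc3ccccc3)nc2c(=O)[nH]1` with 24%

Of the compounds shown here, three have been tested in an assay on CHO cells for displacement of a labelled ligand from adenosine receptor A1 (Homo sapiens), read by scintillation counting, with a stated time of 120 min, tested at 1 uM; a lower number here means less inhibition, a higher number more inhibition at the concentration tested (going by the name of the read-out). Compound 1 `Cc1nc2sc(-c3ccccc3)nc2c(=O)[nH]1` gives 11%, and compound 2 `COc1cccc(-c2nc3c(=O)[nH]c(C)nc3s2)c1` gives 1%. The two differ by methoxy in place of hydrogen on an aromatic carbon, and the step is a number 10 percentage points lower from compound 1 to compound 2 (within the scatter). Compound 3 `Cc1nc2sc(Nc3ccccc3)nc2c(=O)[nH]1` gives 24% and stands highest of the three; its difference from compound 1 is not broken down here beyond the point that the two cores differ.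

Compound 4 `COc1ccc(Nc2nc3c(=O)[nH]c(C)nc3s2)cc1` has not yet been measured in this assay. It differs from compound 3 by methoxy in place of hydrogen on an aromatic carbon. For the measured compounds named here, this is the same kind of change as the one from compound 1 to compound 2, but not the same: in compound 2 the methoxy sits meta to a large group, whereas in compound 4 it sits para to a large group. Going by the values given here, the only measured step of this kind, from compound 1 to compound 2, stayed within the scatter, so for the step from compound 3 to compound 4 an equally small move is expected, a number 6 percentage points lower from compound 3 to compound 4 (within the scatter), resting on that single pair and on the different place of the group. Compound 4 is therefore estimated at 18%, with a range from 4% to 34%.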

Compound 4, a percentage reported as inhibition, at one concentration (the size of the read-out at that concentration, not a potency): 1%
The estimate for compound 4 lay 17 percentage points above the measured number; the measured number lies below the stated range.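

In this assay, for the compounds shown here, the step on the core of compound 3, with methoxy in place of hydrogen on an aromatic carbon para to a large group, is a number 23 percentage points lower from compound 3 to compound 4 (beyond the scatter), and set beside the earlier step the two cores do not separate: the same change on two cores in this assay, a number 10 percentage points lower (within the scatter) from compound 1 to compound 2 and a number 23 percentage points lower (beyond the scatter) from compound 3 to compound 4, 13 percentage points apart, within the scatter of two such steps On these two pairs, then, the change can be carried from one core to the other without a measurable disagreement between the steps, although only the step on the core of compound 3 lies beyond the scatter on its own. Going by these compounds alone, this does not show that the change has a fixed size across the series, since there are only two pairs, and the methoxy stands at a different place on the ring in compound 2 than in compound 4, so the effects of core and place cannot be told apart.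

The compounds shown leave open what methoxy does on either core when it stands at the same place on the ring, and whether the same holds on the core of compound 1 with the group para to a large group. They also leave open how other groups at this place would read in this assay, such as a hydroxyl, a fluorine, an amine or a longer ether chain.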